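A few compounds are considered here, and "the series" means these few. Any claim that something is new, unique, unknown or untested is made for them only; others in the source may bear on it.

Measured compounds in a functional assay on Lewis lung carcinoma cells (Mus musculus) for antiproliferative activity, read by MTT assay, with a stated time of 24 h; on this read-out higher numbers stand for weaker inhibition and lower numbers for stronger inhibition:
- compound 1 `C=CCc1cc(-c2cccc(C(F)(F)F)c2)ccc1O`: 65900 nM
- compound 2 `C=CCc1cc(-c2cccc([N+](=O)[O-])c2)ccc1O`: > 100000 nM, a limit of the assay
- compound 3 `C=CCc1cc(-c2ccccc2)ccc1O`: > 100000 nM, a limit of the assay

Compound 3 has no numerical value, only the limit > 100000 nM. Its position is the limit of > 100000 nM in this assay, at which 2 of the 3 values shown sit.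

Compound 4 `C=CCc1cc(-c2ccc(F)cc2)ccc1O` differs from compound 3 by one change: fluoro in place of hydrogen on an aromatic carbon. The fluoro takes the place of hydrogen on an aromatic carbon, para to a large group.

The measured steps that bear on this change also involve hydrogen on an aromatic carbon. They are an at least 1.5-fold higher number from compound 1 to compound 3 (0.18 log units; that floor lies within the scatter) and a step that the two limits leave unreadable from compound 2 to compound 3. The first has a floor within the scatter, and the size of the second cannot be read. Neither supports a definite size or direction for the new step, so no step beyond the scatter is expected in this assay.

The estimated step is a number no higher from compound 3 to compound 4 (the limit leaves the size open). The estimate for compound 4 is 100000 nM. The expected range runs from 45000 nM to 200000 nM, and a further limit is a likely outcome.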

Compound 4, half-maximal inhibitory concentration: > 100000 nM
Compound 4: only a limit was reported; the forecaster's own chance of this, stated with the estimate: 65%; the middle value sits exactly at the limit.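

In this assay, compound 3 and compound 4 both give only a limit of the assay, so no step can be read between them: the limit of > 100000 nM in this assay, at which 3 of the 4 values shown sit.

The compounds shown leave open whether fluoro in place of hydrogen on an aromatic carbon changes inhibition at all, and in which direction.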